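From methyl to thiophen-2-yl on a sulfonyl sulfur

The source may hold more compounds than are shown below. What is called first, only, known or untested is meant among the compounds shown, and "the series" means these compounds.

Compound 1 `CS(=O)(=O)N1C(=O)COC12C=CC(=O)C=C2` has been tested in a functional assay on MDA-MB-231 cells (Homo sapiens) for inhibition, read by sulforhodamine B assay, with a stated time of 74 h; on this read-out lower numbers stand for stronger inhibition and higher numbers for weaker inhibition. There compound 1 gives > 10000 nM, which is a limit of the assay and not a number. Compound 2 `O=C1C=CC2(C=C1)OCC(=O)N2S(=O)(=O)c1ccccc1C(F)(F)F` gives > 10000 nM, which is also a limit. The measurements so far therefore come to one shared result: the limit of > 10000 nM in this assay, at which 2 of the 2 values shown sit. Neither compound has a true potency number, so they cannot be ranked against each other.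

Compound 3 `O=C1C=CC2(C=C1)OCC(=O)N2S(=O)(=O)c1cccs1` keeps the core of compound 1 but has thiophen-2-yl in place of methyl on a sulfonyl sulfur. Within the data shown here, no measured pair shows what this swap does. Compound 2 also carries a different group on the sulfonyl sulfur and still gives the limit > 10000 nM, so only a modest move towards stronger inhibition in this assay is expected, and compound 3 may well stay at the limit. The expected change is an at least 1.6-fold lower number from compound 1 to compound 3 (0.22 log units; that floor lies within the scatter). For compound 3 the estimated value is 6000 nM, with an expected range from 800 nM to 20000 nM.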

Compound 3, half-maximal inhibitory concentration: 20 nM
The estimate for compound 3 lay 300-fold (2.48 log units) above the measured number, outside the stated range (below it).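

Going by these compounds, putting thiophen-2-yl in place of methyl on a sulfonyl sulfur gives an at least 500-fold lower number from compound 1 to compound 3 (2.69 log units; beyond the scatter) in this assay, so the group at this position can decide between no measurable inhibition and strong inhibition, and the true size of this step stays unknown. Among these compounds, compound 3 is also the first compound here with a true potency number instead of a limit, which gives any later compound something to be ranked against. Simply replacing methyl is not enough, as compound 2 carries another group on the sulfonyl sulfur and remains with compound 1 at one shared result: the limit of > 10000 nM in this assay, at which 2 of the 3 values shown sit.

Among the compounds shown here, with only one compound below the limit, it remains open which feature of thiophen-2-yl matters, whether the ring itself, its sulfur or its five-membered shape. A plain phenyl, a furan-2-yl or a thiophen-3-yl on the sulfonyl sulfur would help to separate these possibilities, while a thiophen-2-yl ring carrying a chlorine or a methyl would show how much change this group tolerates.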